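A few compounds are considered here, and "the series" means these few. Any claim that something is new, unique, unknown or untested is made for them only; others in the source may bear on it.

- Compound 1 `O=C1c2ccccc2CN1c1cnc(NCc2c(F)ccc3c2CCO3)n2cnnc12`: 4000 nM
- Compound 2 `Fc1ccc2c(c1CNc1ncc(Oc3ccccc3)c3nncn13)CCO2`: 8000 nM
- Compound 3 `CN(c1ccccc1)c1cnc(NCc2c(F)ccc3c2CCO3)n2cnnc12`: < 2000 nM

In a physicochemical assay for solubility, read by LC-MS, in phosphate buffer, with a stated time of 24 h, at pH 7.4 (a higher number here means a more soluble compound, a lower number a less soluble compound), compound 3 gives < 2000 nM. From the compounds shown here alone, this is a limit of the assay and not a number, so the true position of compound 3 remains unknown.

Compound 4 `O=C(Nc1cnc(NCc2c(F)ccc3c2CCO3)n2cnnc12)c1ccccc1` carries benzamido in place of methyl(phenyl)amino on an aromatic carbon.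

Three measured steps change the group on that same carbon. The step of an at least 4.0-fold lower number from compound 2 to compound 3 (0.60 log units; beyond the scatter) lies beyond the scatter, while an at least 2.0-fold lower number from compound 1 to compound 3 (0.30 log units; that floor lies within the scatter) has a floor within it, and a 2.0-fold higher number from compound 1 to compound 2 (0.30 log units; within the scatter) also lies within it. The closest guide is compound 1, which also has a carbonyl in this group and gives 4000 nM. Compound 4 is therefore expected to land in the same region, though it may also fall at the assay limit.

The expected change is an at least 1.5-fold higher number from compound 3 to compound 4 (0.17 log units; that floor lies within the scatter), small and probably upward, although the starting limit leaves its true size open. The estimate for compound 4 is 3000 nM, with an expected range from 1000 nM to 9000 nM.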

Compound 4, solubility: 2000 nM
The estimate for compound 4 lay 1.5-fold (0.18 log units) above the measured number, within the range that was stated.
By their numbers in this assay, from the lowest: compounds 4, 1 and 2 (each within the scatter of the next, the first and the last beyond it).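

On this aromatic carbon, benzamido can now be set against phenoxy in this assay, and the two are separated: a 4.0-fold lower number from compound 2 to compound 4 (0.60 log units; beyond the scatter). Benzamido and the group on compound 1, which also has a carbonyl, cannot be told apart, since the result is a 2.0-fold lower number from compound 1 to compound 4 (0.30 log units; within the scatter). Against methyl(phenyl)amino, the data give only a number no lower from compound 3 to compound 4 (the limit leaves the size open). The value of compound 3 is a limit of the assay and not a number: the limit of < 2000 nM in this assay, at which 1 of the 4 values shown sits.

Every group shown on this carbon contains a six-membered aromatic ring of carbon only, so it remains open how a group without one, such as a simple amine or a carboxylic acid, would read here. From the compounds shown here alone, it is also open whether the amide hydrogen of benzamido plays any part, which a version with a methyl on that nitrogen could test.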